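A few compounds are considered here, and "the series" means these few. Any claim that something is new, unique, unknown or untested is made for them only; others in the source may bear on it.

Compound 3 `NC(=O)c1c(NC(=O)c2ccccc2Cl)sc2c1CCN(C(=O)Nc1ccccc1Cl)C2` is the point of departure. In a functional assay on HeLa cells (Homo sapiens) for antiproliferative activity, with a stated time of 24 h (a lower number here means a stronger inhibitor, a higher number a weaker inhibitor), compound 3 gives 45400 nM, the lowest of the two plain numbers shown, yet its neighbour compound 2 `NC(=O)c1c(NC(=O)c2ccccc2Cl)sc2c1CCN(C(=S)Nc1ccccc1)C2` gives 46700 nM, and the two differ by a 1.0-fold lower number from compound 2 to compound 3 (0.01 log units; within the scatter), so no order can be read between them. Compound 1 `NC(=O)c1c(NC(=O)c2ccccc2Cl)sc2c1CCN(Cc1ccccc1F)C2` reaches only the limit > 50000 nM in this assay (the limit of > 50000 nM in this assay, at which 1 of the 3 values shown sits). From compound 1 the steps to the two measured analogues, an at least 1.0-fold lower number from compound 1 to compound 2 (0.02 log units; that floor lies within the scatter) and an at least 1.1-fold lower number from compound 1 to compound 3 (0.04 log units; that floor lies within the scatter), are floors that also sit within the scatter.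

Compound 4 `Cc1ccccc1NC(=S)N1CCc2c(sc(NC(=O)c3ccccc3Cl)c2C(N)=O)C1` arises from compound 3 by a group of 10 heavy atoms (8 carbon, 1 nitrogen, 1 sulfur; one six-membered aromatic ring of carbon only) in place of a group of 10 heavy atoms (7 carbon, 1 nitrogen, 1 oxygen, 1 chlorine; one six-membered aromatic ring of carbon only), on an amine nitrogen in a ring. Within the data shown here, the only measured step that bears on this exchange is the one from compound 2 to compound 3, which swapped a thiourea for a chlorophenyl urea at the same nitrogen and moved by a 1.0-fold lower number from compound 2 to compound 3 (0.01 log units; within the scatter). Returning to a thiourea, now with an added methyl on the ring, is therefore expected to produce no step beyond the scatter, that is a 1.0-fold lower number from compound 3 to compound 4 (0.00 log units; within the scatter). Compound 4 is accordingly estimated at 45000 nM, within a range of 20000 nM to 100000 nM.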

Compound 4, half-maximal inhibitory concentration: > 50000 nM
Compound 4: a limit, no number; the forecaster's own chance of this, stated with the estimate: 35%; at least 1.1-fold (0.04 log units) between middle value and limit.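

In this assay compound 4 gives only a limit, not a number. The exchange of (2-chlorophenyl)carbamoyl for the new group on the amine nitrogen in a ring gives an at least 1.1-fold higher number from compound 3 to compound 4 (0.04 log units; that floor lies within the scatter), and methyl in place of hydrogen on an aromatic carbon gives an at least 1.0-fold higher number from compound 2 to compound 4 (0.02 log units; that floor lies within the scatter), so neither change can be ordered, and the step between compound 1 and compound 4 cannot be read. Across compound 1, compound 2, compound 3 and compound 4, this nitrogen has now carried four different groups without a step shown beyond the scatter, and the limit is now shared more widely: the limit of > 50000 nM in this assay, at which 2 of the 4 values shown sit.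

As far as these compounds go, whether an amine or a carboxylic acid in place of the aromatic ring of these groups would give a clearly lower number stays open. The same holds for a longer chain on this nitrogen.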